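Shortening the Side Chain of a Cyclic Phosphate Nucleoside

The source may hold more compounds than are shown below. What is called first, only, known or untested is meant among the compounds shown, and "the series" means these compounds.

Compound 1 `CCCCCCCCc1cn([C@H]2C[C@@H]3OP(=O)(O)OC[C@H]3O2)c(=O)[nH]c1=O` carries an octyl chain on its core and a cyclic phosphate on its sugar. For the measured compounds named here, in a functional assay on L1210 cells (Mus musculus) (on this read-out higher numbers stand for weaker inhibition and lower numbers for stronger inhibition), compound 1 gives 193 ug/mL, the only number among the two values shown. Compound 2 `CCCCc1cn([C@H]2C[C@H](O)[C@@H](CO)O2)c(=O)[nH]c1=O`, which carries a butyl chain and an open sugar, reaches only a limit of this assay, > 500 ug/mL, so no number is reported for it. Compound 3 `CCCc1cn([C@H]2C[C@@H]3OP(=O)(O)OC[C@H]3O2)c(=O)[nH]c1=O` keeps the cyclic phosphate of compound 1, and the change is hydrogen in place of pentyl on a saturated chain carbon, three bonds along the chain from an aromatic carbon. Going by the values given here, no step between measured compounds is available, so the direction rests on compound 2 alone, whose limit of > 500 ug/mL in this assay, at which 1 of the 2 values shown sits, goes together with a short chain. The step of a 2.6-fold higher number from compound 1 to compound 3 (0.41 log units; beyond the scatter) is expected to weaken inhibition in this assay. Compound 3 is therefore estimated at about 500 ug/mL, within a range from 200 ug/mL to 2000 ug/mL, with a fair chance that only a limit is reported.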

Compound 3, concentration for 50% inhibition: > 500 ug/mL
Compound 3: a limit, no number (the forecaster's own chance of this, stated with the estimate: 60%); the middle value sits exactly at the limit.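

For the compounds shown here, with the cyclic phosphate kept, going from octyl to propyl is the first change in one place that can be read in this assay: the step is an at least 2.5-fold higher number from compound 1 to compound 3 (0.41 log units; beyond the scatter). Compound 3 reaches only a limit of the assay, > 500 ug/mL, so this step marks the smallest possible size of the change, and the true loss of inhibition may be larger. Compound 2 differs from compound 1 in both chain and sugar, whereas compound 3 ties the weakening to the chain alone and shares the limit: the limit of > 500 ug/mL in this assay, at which 2 of the 3 values shown sit.

From the compounds shown here alone, how inhibition runs across chain lengths, such as a hexyl chain or one longer than octyl like decyl, stays open. Going by these compounds, the part played by the cyclic phosphate also stays open: the open sugar appears only with a butyl chain, and an octyl chain on the open sugar would separate the two effects.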